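Chain Extension on the Ester of Two Imidazole Amides

The source may hold more compounds than are shown below. What is called first, only, known or untested is meant among the compounds shown, and "the series" means these compounds.

Measured compounds:
compound 1 `CCCOC(=O)C(Cn1ccnc1)NC(=O)c1ccc(-c2ccccc2)cc1` 790 nM
compound 2 `CC(C)COC(=O)C(Cn1ccnc1)NC(=O)c1ccc(-c2ccccc2)cc1` 970 nM
compound 3 `CCOC(=O)C(Cn1ccnc1)NC(=O)c1c(C)nn(-c2ccccc2)c1Cl` 600 nM

In an assay on HL-60 cells for inhibition of cytochrome P450 26A1 (Homo sapiens), read by HPLC, using microsomes and NADPH, with a stated time of 30 min (a lower number here means a stronger inhibitor, a higher number a weaker inhibitor), compound 1 gives 790 nM and compound 2 gives 970 nM; the change between them is methyl in place of hydrogen on a saturated chain carbon bound to two saturated chain carbons, and it gave a 1.2-fold higher number from compound 1 to compound 2 (0.09 log units; within the scatter). Compound 3 gives 600 nM; the difference between its core and the core of compound 1 is not broken down here. Compound 4 `CCCOC(=O)C(Cn1ccnc1)NC(=O)c1c(C)nn(-c2ccccc2)c1Cl` carries the change (methyl in place of hydrogen on a saturated chain carbon, two bonds along the chain from an oxygen next to a carbonyl group). This is the same kind of change as from compound 1 to compound 2, though here the place is two bonds along the chain from an oxygen next to a carbonyl group, rather than bound to two saturated chain carbons. Resting on the step from compound 1 to compound 2, the step from compound 3 to compound 4 in this assay is expected to be a 1.1-fold higher number from compound 3 to compound 4 (0.03 log units; within the scatter). Compound 4 is therefore estimated at 650 nM, between 330 nM and 1300 nM.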

Compound 4, half-maximal inhibitory concentration: 620 nM
Compound 4: the middle estimate sits 1.0-fold (0.02 log units) above what was measured, and the stated range covers the measured number.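

In this assay, methyl in place of hydrogen on a saturated chain carbon of the ester gave a 1.0-fold higher number from compound 3 to compound 4 (0.01 log units; within the scatter) on the core of compound 3. Set beside the earlier step, the change reads the same on both cores: the same change on two cores in this assay, a 1.2-fold higher number (0.09 log units; within the scatter) from compound 1 to compound 2 and a 1.0-fold higher number (0.01 log units; within the scatter) from compound 3 to compound 4, 1.2-fold (0.07 log units) apart, within the scatter of two such steps. This shows that, on these two cores, the small step seen on one matched the small step seen on the other, but since both lie within the scatter, it does not show that a real effect was carried across, nor that the same would hold on other cores.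

The compounds shown leave open what a longer chain on the ester would do on either core. They also leave open whether a carboxylic acid in place of the ester would keep the numbers seen here.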